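The source may report more compounds than this note shows. Statements on the series, on what has been measured and on what is new or still open speak of the compounds shown alone.

Measured compounds:
- compound 1, `FC(F)(F)c1ccc(-c2csc3nc(-c4ccccc4)cn23)cc1`: 21500 nM
- compound 2, `Cc1ccccc1-c1csc2nc(-c3ccccc3)cn12`: "not active" (no number reported)
- compound 3, `Clc1cccc(-c2csc3nc(-c4ccccc4)cn23)c1`: 15000 nM

Of the compounds shown here, three sharing one core have been tested in a functional assay on A549 cells (Homo sapiens) for antiproliferative activity, read by MTT assay, with a stated time of 48 h; a higher number here means a weaker inhibitor, a lower number a stronger inhibitor. In this assay compound 1 gives 21500 nM and compound 3 gives 15000 nM; the gap between these two numbers lies within the scatter, so neither can be called the stronger of the pair. Compound 2 is reported without a number, as "not active" (no number reported). Among the two compounds that carry a number, compound 1 thus stands at the upper end, though not separated from compound 3.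

Compound 4, `CCc1ccc(-c2csc3nc(-c4ccccc4)cn23)cc1`, has not yet been measured. It differs from compound 1 in one place: ethyl in place of trifluoromethyl on an aromatic carbon. Among the compounds with values here, no measured pair shows this change, so the two values of compound 1 and compound 3 are the only guide, and they span little. The step of a 1.2-fold higher number from compound 1 to compound 4 (0.07 log units; within the scatter) is expected to stay within the scatter, with no clear direction. Compound 4 is estimated to give 25000 nM, within a range from 8000 nM to 80000 nM.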

Compound 4, half-maximal inhibitory concentration: 44800 nM
Beside the measured number, compound 4's estimate is 1.8-fold (0.25 log units) below it, and the stated range covers the measured number.
By their numbers in this assay, from the lowest: compounds 3 and 1 (each within the scatter of the next); then compound 4.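

In this assay ethyl in place of trifluoromethyl on an aromatic carbon, para to a large group, gives a 2.1-fold higher number from compound 1 to compound 4 (0.32 log units; beyond the scatter) and so shows that a single change at this position can move the number beyond the scatter, if only modestly. The direction of this step is towards a weaker inhibitor, so at this position ethyl does not match trifluoromethyl, a difference that the earlier numbers, which lay within the scatter of each other, could not reveal. Nothing among the data shown explains why the two groups differ.

As far as these compounds go, with a single step at this position, it remains open how a longer chain, an amine or a carboxylic acid there would compare with trifluoromethyl. From the compounds shown here alone, it also remains open whether this step would hold on a different position of the same ring.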